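Ethyl on the pyrimidinone ring: expected clearance in rat microsomes

The source may hold more compounds than are shown below. What is called first, only, known or untested is meant among the compounds shown, and "the series" means these compounds.

Measured so far:
compound 1 `CC(C)Oc1cc(Oc2ccc(S(C)(=O)=O)cc2)cc(-c2nccc(=O)[nH]2)c1` — 105 mL/min/kg
compound 2 `CC(C)Oc1cc(Oc2cnc(C(=O)N(C)C)nc2)cc(-c2nccc(=O)[nH]2)c1` — < 25.4 mL/min/kg

In an ADME assay on microsomes from liver (Rattus norvegicus) for metabolic stability (a lower number here means slower removal, a higher number faster removal of the compound), compound 1 gives 105 mL/min/kg and is the only compound with a number shown. Compound 2 sits at the limit of < 25.4 mL/min/kg in this assay, at which 1 of the 2 values shown sits, which is a limit of this assay and not a number. Within the data shown here, no step between the two measured compounds is given, so only their two values stand as they are.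

Compound 3 `CCc1cnc(-c2cc(Oc3ccc(S(C)(=O)=O)cc3)cc(OC(C)C)c2)[nH]c1=O` is reached from compound 1 by the change (ethyl in place of hydrogen on an aromatic carbon). With no measured step of this kind in the set, the expectation rests on compound 1 alone. The step of a 1.1-fold higher number from compound 1 to compound 3 (0.06 log units; within the scatter) is expected to be small, in the direction of faster removal, and not clearly beyond the usual scatter. Compound 3 is therefore estimated at 120 mL/min/kg in this assay, with a range from 60 mL/min/kg to 240 mL/min/kg.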

Compound 3, clearance: 171 mL/min/kg
The estimate for compound 3 lay 1.4-fold (0.15 log units) below the measured number; the range from low to high includes it.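

In this assay, ethyl in place of hydrogen on an aromatic carbon of the six-membered ring with 2 nitrogen gives a 1.6-fold higher number from compound 1 to compound 3 (0.21 log units; within the scatter) and so cannot be told apart from repeat measurements. This position therefore takes the ethyl group without a step beyond the scatter, though that reading rests on one pair, on the core of compound 1 alone. No measured property at hand bears on this step.

As far as these compounds go, whether a longer chain, an amine or a carboxylic acid at this position would give a step beyond the scatter remains open. Also open, from the compounds shown here alone, is how ethyl would read at this position on compound 2, whose < 25.4 mL/min/kg is a limit of the assay and not a number.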